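The compounds below may be only part of what the source reports. "The series", "measured", "known", "first", "only" and "open" are said of these compounds alone.

Compound 1 `O=C(NCN1CCC(c2cccc[n+]2[O-])CC1)c1ccccc1`, a functional assay on HEK293 cells for agonist activity at D(4) dopamine receptor (Homo sapiens), read by FLIPR; a lower number here means a smaller maximal response, a higher number a larger maximal response: 63%
Compound 2 `Cc1cccc(C(=O)NCN2CCC(c3ccccn3)CC2)c1`, this assay: 67%
Compound 3 `Cc1ccc([N+](=O)[O-])cc1NC(=O)CN1CCC(c2cccc[n+]2[O-])CC1`, this assay: 76%

Compound 1 has the lowest of the three numbers in this assay. Compound 2 lies close to it, within the scatter, so no order between the two is claimed. Compound 3 is the furthest away, beyond the scatter. No two of the measured compounds differ in one place only, so no single change can be read from them.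

The unmeasured compound 4 `O=C(NCN1CCC(c2cccc[n+]2[O-])CC1)c1ccccn1` is reached from compound 1 by one change: pyridin-2-yl in place of phenyl on a carbonyl carbon. Nothing in the measured set shows what this change does in this assay, since neither compound 2 nor compound 3 differs from compound 1 in just this place. The expectation is therefore no step beyond the scatter, in either direction, with a wide range.

Compound 4 is expected to give about 65% in this assay, between 50% and 80%. This estimate implies a step of a number 2 percentage points higher from compound 1 to compound 4 (within the scatter), expected to stay within the scatter.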

Compound 4, largest response reached (reported as efficacy), in percent of the reference or control that the assay uses: 40%
Compound 4: the middle estimate sits 25 percentage points above what was measured; the measured number lies below the stated range.
By their numbers in this assay, from the lowest: compound 4; then compounds 1, 2 and 3 (each within the scatter of the next, the first and the last beyond it).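

In this assay, for the compounds shown here, the carbonyl carbon's aryl group proves to matter: pyridin-2-yl in place of phenyl gives a number 23 percentage points lower from compound 1 to compound 4 (beyond the scatter), the first step that can be read. The two groups match in heavy-atom count, while the entering ring has a nitrogen and a hydrogen-bond acceptor that phenyl lacks, so a change confined to this ring is enough to move the maximal response beyond the scatter. Nothing available bears on the reason for this step.

Open, from the compounds shown here alone, is whether pyridin-3-yl or pyridin-4-yl on the same carbonyl carbon would give a like step, and whether cyclohexyl would read closer to phenyl or to pyridin-2-yl. Also open, going by these compounds, is whether pyridin-2-yl would give a like step on the core of compound 2.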